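Swapping an Ester Side Chain on a Nitrophenyl Scaffold

The source may hold more compounds than are shown below. What is called first, only, known or untested is meant among the compounds shown, and "the series" means these compounds.

Of the compounds shown here, two sharing the same core have been tested so far. Compound 1 `CCCCC1=C(C(=O)OCC)C(c2cccc([N+](=O)[O-])c2)C(C(=O)OCC)=C(C)N1` carries a butyl group and two ethyl esters; in a functional assay on HEK293 cells for antagonist activity at Voltage-dependent L-type calcium channel subunit alpha-1C (Oryctolagus cuniculus), read by FLIPR (on this read-out lower numbers stand for stronger inhibition and higher numbers for weaker inhibition), compound 1 gives 20 nM. Compound 2 `COC(=O)C1=C(C)NC(C)=C(C(=O)OCC(C)[N+](=O)[O-])C1c1cccc([N+](=O)[O-])c1` instead carries a methyl ester on one side and, on the other, an ester whose chain bears a nitro group; in this assay compound 2 gives 108 nM, which is the higher of the two numbers, a gap to compound 1 that goes beyond the usual scatter.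

Compound 3 `COC(=O)C1=C(C)NC(C)=C(C(=O)OCCc2ccc(Cl)cc2)C1c1cccc([N+](=O)[O-])c1` has not yet been measured. It keeps everything in compound 2 except the ester side chain, where the change is 4-chlorobenzyl in place of 1-nitroethyl on a saturated chain carbon bound to an oxygen next to a carbonyl group. Within the data shown here, no measured pair shows exactly this kind of swap, so the expectation rests on the two values alone and is uncertain. The step from compound 2 to compound 3 in this assay is expected to be a 2.4-fold lower number from compound 2 to compound 3 (0.38 log units; beyond the scatter), a move toward a lower number that may only just exceed the scatter. Compound 3 is therefore estimated at 45 nM, with a plausible range from 12 nM to 170 nM.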

Compound 3, half-maximal inhibitory concentration: 8 nM
Compound 3: the middle estimate sits 5.6-fold (0.75 log units) above what was measured, and the stated range ends above it.
By their numbers in this assay, from the lowest: compound 3; then compound 1; then compound 2.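

At the ester side chain, on a saturated chain carbon bound to an oxygen next to a carbonyl group, the result in this assay depends strongly on the attached group: 4-chlorobenzyl in place of 1-nitroethyl gives a 14-fold lower number from compound 2 to compound 3 (1.13 log units; beyond the scatter). Among these compounds, this is the first pair here that differs in only one place, so it gives the first direct reading of this position. It shows that a larger group of 8 heavy atoms, with one six-membered aromatic ring of carbon only and 0 hydrogen-bond acceptors, can replace a group of 5 heavy atoms with 2 hydrogen-bond acceptors without any loss of inhibition, and no available evidence identifies which of these differences matters.

As far as these compounds go, what the chlorine itself contributes remains open, and a plain 2-phenylethyl chain on the same ester would separate its contribution from that of the ring. From the compounds shown here alone, it also remains open whether a chain ending in an amine or a longer chain without a ring would move the number in the same direction as 2-(4-chlorophenyl)ethyl.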